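Swapping Fluoro for Methoxymethyl on an Acrylamide-Like Chain

The compounds below may be only part of what the source reports. "The series", "measured", "known", "first", "only" and "open" are said of these compounds alone.

In an ADME assay for pharmacokinetics, read by LC-MS, in phosphate buffer, with a stated time of 120 min, at pH 7.4, tested at 1 uM, in the presence of a further agent that is not named here (a lower number here means that the compound disappears faster, a higher number that the compound lasts longer), compound 1 `C=C(Cl)C(=O)Nc1ccccc1` gives 0.05 h.

Compound 2 `C=C(F)C(=O)Nc1ccccc1` gives > 8.53 h, which is a limit of the assay and not a number.

Compound 3 `C=C(COC)C(=O)Nc1ccccc1` carries methoxymethyl in place of fluoro on a double-bonded chain carbon bound to a carbonyl carbon. For the measured compounds named here, one measured step bears on this place: replacing chloro with fluoro gave an at least 170-fold higher number from compound 1 to compound 2 (2.23 log units; beyond the scatter), a large change beyond the scatter. The group here can therefore move the half-life strongly, but methoxymethyl matches neither measured group. Going by the values given here, with only that step as a guide, a result between the two measured compounds is expected, nearer the long-lasting end. The expected change is an at least 2.8-fold lower number from compound 2 to compound 3 (0.45 log units; beyond the scatter), towards a lower number, with wide uncertainty. For compound 3, the estimated half-life is 3 h, with an expected range of 0.6 h to 12 h.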

Compound 3, half-life: 4.02 h
Estimate against measurement, compound 3: 1.3-fold (0.13 log units) below; measured number inside the range.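

Methoxymethyl in place of chloro gives an 80-fold higher number from compound 1 to compound 3 (1.91 log units; beyond the scatter), so in this assay a long half-life at this place is not confined to fluoro. Methoxymethyl in place of fluoro gives an at least 2.1-fold lower number from compound 2 to compound 3 (0.32 log units; beyond the scatter), which shows that the group entering here can still shorten the half-life when chloro is not involved, although the true size of this step remains unknown. Compound 2 stands at a limit of the assay, which is not a number: the limit of > 8.53 h in this assay, at which 1 of the 3 values shown sits.

On these data alone, it remains open whether the oxygen of methoxymethyl matters, which a propyl chain at this place could test. It is also unclear how an amine, such as dimethylaminomethyl, or a carboxylic acid would behave on this double-bonded chain carbon bound to a carbonyl carbon.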